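A few compounds are considered here, and "the series" means these few. Any claim that something is new, unique, unknown or untested is made for them only; others in the source may bear on it.

Going by the values given here, compound 3 `O=c1ccoc2cc(OCc3cn(Cc4ccc(Cl)cc4Cl)nn3)ccc12` is the only member of this set with a measured number: in a functional assay on A549 cells (Homo sapiens) for cytotoxicity, read by MTT assay, with a stated time of 48 h (on this read-out lower numbers stand for stronger inhibition and higher numbers for weaker inhibition), compound 3 gives 5260 nM. Compound 1 `O=c1ccoc2cc(OCc3cn(Cc4ccc([N+](=O)[O-])cc4)nn3)ccc12` reaches only the limit > 100000 nM in this assay. Compound 2 `O=c1ccoc2cc(OCc3cn(Cc4cccc(Br)c4)nn3)ccc12` likewise reaches only the limit > 100000 nM. Both of these limits sit at the limit of > 100000 nM in this assay, at which 2 of the 3 values shown sit. Compound 4 `O=c1ccoc2cc(OCc3cn(Cc4ccccc4Cl)nn3)ccc12` differs from compound 3 by hydrogen in place of chloro on an aromatic carbon. The steps of an at least 19-fold lower number from compound 1 to compound 3 (1.27 log units; beyond the scatter) and an at least 19-fold lower number from compound 2 to compound 3 (1.27 log units; beyond the scatter) show that the 2,4-dichlorophenyl group stands apart from the other aryl groups measured, so taking away one of its two chloro groups is expected to raise the number, though the size cannot be read from two limits. Compound 4 is therefore estimated at 20000 nM, with a range from 5000 nM to 100000 nM. The step thus expected is a 3.8-fold higher number from compound 3 to compound 4 (0.58 log units; beyond the scatter).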

Compound 4, half-maximal inhibitory concentration: > 100000 nM
Compound 4: a limit, no number; the forecaster's own chance of this, stated with the estimate: 35%; middle value at least 5.0-fold (0.69 log units) away from the limit.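

Going from 2,4-dichlorobenzyl to 2-chlorobenzyl gives an at least 19-fold higher number from compound 3 to compound 4 (1.27 log units; beyond the scatter) in this assay. Going by these compounds alone, the chloro group para to a large group therefore matters here: the remaining chloro group alone does not give a measurable number, which the earlier compounds could not show. Compound 4 gives only a limit, and its steps from compound 1 and compound 2 cannot be read: the limit of > 100000 nM in this assay, at which 3 of the 4 values shown sit.

From the compounds shown here alone, whether a methyl or methoxy group in that place would restore a measurable number stays open. Going by these compounds, it is also open whether the chloro group para to a large group would suffice without the other chloro group.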